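The source may report more compounds than this note shows. Statements on the series, on what has been measured and on what is new or still open speak of the compounds shown alone.

Of the compounds shown here, three of one series have been tested in an ADME assay on HeLa cells (Homo sapiens) for cytotoxicity, read by MTT assay; a higher number here means a weaker inhibitor, a lower number a stronger inhibitor. Compound 1, `N#Cc1c(-c2ccccc2O)c(C#N)c(=O)n(/N=C/c2cn(-c3ccccc3)nc2-c2ccccc2)c1N`, in this assay gives > 200 ug/mL, which is a limit of the assay and not a number. Compound 2, `N#Cc1c(-c2ccc(Cl)cc2)c(C#N)c(=O)n(/N=C/c2cn(-c3ccccc3)nc2-c2ccccc2)c1N`, in this assay gives > 200 ug/mL, again a limit. Compound 3, `N#Cc1c(-c2cccc(F)c2)c(C#N)c(=O)n(/N=C/c2cn(-c3ccccc3)nc2-c2ccccc2)c1N`, in this assay gives > 200 ug/mL, also a limit. The steps between them, a step that the two limits leave unreadable from compound 1 to compound 2, a step that the two limits leave unreadable from compound 1 to compound 3 and a step that the two limits leave unreadable from compound 2 to compound 3, have no readable size because all three values sit at the limit of > 200 ug/mL in this assay, at which 3 of the 3 values shown sit. Compound 4, `COc1ccc(-c2c(C#N)c(N)n(/N=C/c3cn(-c4ccccc4)nc3-c3ccccc3)c(=O)c2C#N)cc1`, has not yet been measured. It differs from compound 3 in one place: 4-methoxyphenyl in place of 3-fluorophenyl on an aromatic carbon. Among the measured compounds shown here, none of the measured steps gives a readable size that bears on this change; the three values show only that three different substituents at this place all left the cells untouched up to the limit. Compound 4 is therefore expected to sit at the same limit, and the step that the limit leaves unreadable from compound 3 to compound 4 is expected to stay within the scatter. The estimate for compound 4 in this assay is 300 ug/mL, ranging from 150 ug/mL to 800 ug/mL.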

Compound 4, half-maximal inhibitory concentration: > 200 ug/mL
Compound 4 gave a limit, no number; the forecaster's own chance of this, stated with the estimate: 85%; the middle value is on the limit's open side.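

Among the compounds shown here, no step from compound 4 to compound 1, compound 2 or compound 3 can be read, because all four compounds end at one limit: the limit of > 200 ug/mL in this assay, at which 4 of the 4 values shown sit.

The compounds shown leave open how these four compare in this assay beyond that limit.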